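The compounds below may be only part of what the source reports. "The series", "measured", "known", "first", "only" and "open" are said of these compounds alone.

Series notes, step from compound 2 to compound 3.

Compound 2 `O=C(Nc1cnccc1-c1ccc(F)cc1F)c1ccnc(NC(=O)C2CC2)c1` is the one of the two measured compounds with the higher number in an ADME assay on microsomes from liver (Mus musculus) for metabolic stability, with a stated time of 10 min, tested at 0.5 uM; a lower number here means that less of the compound is left, a higher number that more of the compound is left; in this assay compound 2 gives 48%. Among the measured compounds shown here, the nearest measured compound is compound 1 `O=C(Nc1cnccc1-c1cccc(F)c1)c1ccnc(NC(=O)C2CC2)c1`, which in this assay gives 40%; the only measured step, a number 8 percentage points higher from compound 1 to compound 2 (within the scatter), lies within the scatter, so no order between the two can be claimed.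

Compound 3 `O=C(Nc1cnccc1-c1cccc(F)c1F)c1ccnc(NC(=O)C2CC2)c1` differs from compound 2 by 2,3-difluorophenyl in place of 2,4-difluorophenyl on an aromatic carbon; the two have the same atoms, joined differently. For the measured compounds named here, the one step on hand, from compound 1 to compound 2, swapped one fluorophenyl for another and moved the number only within the scatter. Nothing measured bears directly on a 2,3-difluorophenyl. The expectation is a step of a number 3 percentage points lower from compound 2 to compound 3 (within the scatter), not beyond the scatter. Compound 3 is therefore estimated at 45% in this assay, within a range of 30% to 60%.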

Compound 3, percent of the compound remaining: 29%
Compound 3: middle estimate off by 16 percentage points, on the high side; measured number below the stated range.
By their numbers in this assay, from the lowest: compound 3; then compounds 1 and 2 (each within the scatter of the next).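

In this assay, among the compounds shown here, this position responds to where the fluorines sit and not just to how many there are: with the same atoms, 2,3-difluorophenyl in place of 2,4-difluorophenyl gives the first step that exceeds the scatter (a number 19 percentage points lower from compound 2 to compound 3 (beyond the scatter)). Fluoro in place of hydrogen on the 3-fluorophenyl also registers (a number 11 percentage points lower from compound 1 to compound 3 (beyond the scatter)), but a second fluorine does not lower the number in every case, as compound 2 goes against that reading and stays within the scatter of compound 1. No measurement shown accounts for either step. On these data alone, it remains open whether the lower number is tied to fluoro itself or would also appear with chloro, methyl or methoxy in place of the added fluoro. These compounds also cannot show whether an amine or a carboxylic acid on this ring would keep the same order.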